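Hexylsulfanyl replaces cyclopentylamino at the assay limit

The compounds below may be only part of what the source reports. "The series", "measured", "known", "first", "only" and "open" are said of these compounds alone.

Compound 1 `CCCSc1nc(N)nc2c1ncn2/C=C1/CC1(CO)CO`: > 300000 nM
Compound 2 `Nc1nc(NC2CCCC2)c2ncn(/C=C3/CC3(CO)CO)c2n1`: > 300000 nM

Both entries come from an ADME assay on HFF cells (Homo sapiens) for cytotoxicity, with a stated time of 8 days; a higher number here means that more compound is tolerated, a lower number that less compound is tolerated. In this assay, compound 2 stands at > 300000 nM, which is a limit and not a number. The whole record so far is the limit of > 300000 nM in this assay, at which 2 of the 2 values shown sit.

Compound 3 `CCCCCCSc1nc(N)nc2c1ncn2/C=C1/CC1(CO)CO` has not yet been measured. Its difference from compound 2 is hexylsulfanyl in place of cyclopentylamino on an aromatic carbon.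

Among the measured compounds shown here, only one measured step bears on this change, a step that the two limits leave unreadable from compound 1 to compound 2. It swaps the same kind of groups in the opposite sense, with a propylsulfanyl chain rather than hexylsulfanyl, but its size cannot be read, so it offers no number to carry over. Compound 1 is the nearest relative with a sulfanyl chain, and its > 300000 nM is also a limit.

Little change is therefore expected, and any readable shift should be modest and towards less compound tolerated. The expected step is an at least 1.2-fold lower number from compound 2 to compound 3 (0.07 log units; that floor lies within the scatter). For compound 3 the estimate is 250000 nM, with an expected range from 90000 nM to 300000 nM.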

Compound 3, half-maximal cytotoxic concentration: > 300000 nM
Compound 3 gave a limit, no number; the forecaster's own chance of this, stated with the estimate: 60%; at least 1.2-fold (0.07 log units) between middle value and limit.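

Compound 3 also ends at a limit rather than a number, so its steps from compound 1 and compound 2 cannot be read: the limit of > 300000 nM in this assay, at which 3 of the 3 values shown sit.

The compounds shown leave open what concentration in this assay would harm the cells for any of them, and whether propylsulfanyl, hexylsulfanyl and cyclopentylamino differ there at all.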